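The compounds below may be only part of what the source reports. "The series", "measured", "known", "first", "only" and "open" are said of these compounds alone.

In a functional assay on NCI-H1975 cells (Homo sapiens) for cytotoxicity, read by MTT assay, with a stated time of 72 h (a higher number here means a weaker inhibitor, a lower number a stronger inhibitor), compound 1 `CN1CCN(c2ccc(Nc3ncc4nc(Nc5cccc([N+](=O)[O-])c5)n(C5CCCC5)c4n3)cc2)CC1` gives 980 nM and compound 2 `Cc1cccc(Nc2nc3cnc(Nc4ccc(N5CCN(C)CC5)cc4)nc3n2C2CCCC2)c1` gives 560 nM, two values within the scatter of each other. Compound 3 `CN1CCN(c2ccc(Nc3ncc4nc(Nc5cccc(C(=O)Nc6ccc(Cl)cc6)c5)n(C5CCCC5)c4n3)cc2)CC1` differs from compound 2 by (4-chlorophenyl)carbamoyl in place of methyl on an aromatic carbon, with (4-chlorophenyl)carbamoyl in place of methyl on an aromatic carbon, meta to a large group. Among the compounds with values here, the only measured step at this place, a 1.8-fold lower number from compound 1 to compound 2 (0.24 log units; within the scatter), involves no group of this size, so it guides the new change only weakly. No step beyond the scatter is expected in this assay, in either direction, and the expected step is a 1.1-fold higher number from compound 2 to compound 3 (0.03 log units; within the scatter). For compound 3 the estimated value is 600 nM, with an expected range of 150 nM to 2500 nM.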

Compound 3, half-maximal inhibitory concentration: 4010 nM
The estimate for compound 3 lay 6.7-fold (0.82 log units) below the measured number; the whole stated range lies below it.
By their numbers in this assay, from the lowest: compounds 2 and 1 (each within the scatter of the next); then compound 3.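

In this assay this position, meta to a large group, proves sensitive to the substituent: methyl and nitro gave values within the scatter of each other, but (4-chlorophenyl)carbamoyl gives a 7.2-fold higher number from compound 2 to compound 3 (0.85 log units; beyond the scatter), and likewise a 4.1-fold higher number from compound 1 to compound 3 (0.61 log units; beyond the scatter). Nothing available explains this loss.

As far as these compounds go, it remains open whether the step belongs to the amide link or to the 4-chlorophenyl ring. A primary carboxamide, a carboxylic acid or an aminomethyl group at this place would help separate the two.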